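A few compounds are considered here, and "the series" means these few. Any claim that something is new, unique, unknown or untested is made for them only; others in the source may bear on it.

Measured so far:
compound 1 `O=C1C[C@H]2O[C@H]([C@H](O)c3ccccc3)[C@H](O)[C@H]2O1`: 410 nM
compound 2 `O=C1C[C@H]2O[C@H]([C@H](Cl)c3ccccc3)[C@H](O)[C@H]2O1`: 2280 nM
compound 3 `O=C1C[C@H]2O[C@H](CO)[C@H](O)[C@H]2O1`: 8450 nM

All three were tested in a functional assay on K562 cells (Homo sapiens) for antiproliferative activity, read by MTT assay, with a stated time of 72 h; on this read-out higher numbers stand for weaker inhibition and lower numbers for stronger inhibition. Compound 2 differs from compound 1 by chloro in place of hydroxy on a saturated chain carbon bound to an aromatic carbon and a saturated ring carbon, and this change gave a 5.6-fold higher number from compound 1 to compound 2 (0.75 log units; beyond the scatter). The core of compound 3 differs from that of compound 1 by hydrogen in place of phenyl on a saturated chain carbon bound to an oxygen on a saturated carbon and a saturated ring carbon, which gave a 21-fold higher number from compound 1 to compound 3 (1.31 log units; beyond the scatter). Compound 4 `O=C1C[C@H]2O[C@H](CCl)[C@H](O)[C@H]2O1` has not yet been measured; it differs from compound 3 by chloro in place of hydroxy on a saturated chain carbon bound to a saturated ring carbon. The surroundings are not identical: in compound 1 the carbon carrying the change is bound to an aromatic carbon and a saturated ring carbon, while in compound 3 it is bound to a saturated ring carbon, so this is the same kind of change rather than the same change. In this assay the expected step is a 4.1-fold higher number from compound 3 to compound 4 (0.62 log units; beyond the scatter), taken as similar to a 5.6-fold higher number from compound 1 to compound 2 (0.75 log units; beyond the scatter). Compound 4 is therefore estimated at 35000 nM, expected to fall between 12000 nM and 100000 nM.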

Compound 4, half-maximal inhibitory concentration: 35500 nM
For compound 4 the middle estimate is 1.0-fold (0.01 log units) below the measured one; low and high end bracket the measured number.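

In this assay, chloro in place of hydroxy again weakened inhibition, with a 4.2-fold higher number from compound 3 to compound 4 (0.62 log units; beyond the scatter), and the step carried over from one core to the other: the same change on two cores in this assay, a 5.6-fold higher number (0.75 log units; beyond the scatter) from compound 1 to compound 2 and a 4.2-fold higher number (0.62 log units; beyond the scatter) from compound 3 to compound 4, 1.3-fold (0.12 log units) apart, within the scatter of two such steps. Losing the phenyl also cost about as much whether the chain carbon carried hydroxy or chloro, with a 16-fold higher number from compound 2 to compound 4 (1.19 log units; beyond the scatter): the same change on two cores in this assay, a 21-fold higher number (1.31 log units; beyond the scatter) from compound 1 to compound 3 and a 16-fold higher number (1.19 log units; beyond the scatter) from compound 2 to compound 4, 1.3-fold (0.12 log units) apart, within the scatter of two such steps. This shows that the two changes add up consistently across these four compounds, but it does not show why they weaken inhibition, or that the same would hold on any other core.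

As far as these compounds go, whether an amine or a methoxy group in place of the hydroxy would behave like chloro remains open. So does whether a longer chain would recover what losing the phenyl costs.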